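Series notes: pyridine to oxazole amides, growth inhibition

A few compounds are considered here, and "the series" means these few. Any claim that something is new, unique, unknown or untested is made for them only; others in the source may bear on it.

Measured so far in an ADME assay on BaF3 cells (Mus musculus) for antiproliferative activity; on this read-out lower numbers stand for stronger inhibition of growth and higher numbers for weaker inhibition of growth:
Compound 1 `Cc1ccc(NC(=O)c2cccc(C(F)(F)F)c2)cc1OCCNC(=O)c1cccnc1`: compound 1 gives > 10000 nM, a limit of the assay.
Compound 2 `Cc1ccc(NC(=O)c2cccc(C(F)(F)F)c2)cc1OCCNC(=O)c1ccno1`: compound 2 gives > 10000 nM, likewise a limit.
Compound 3 `Cc1ccc(NC(=O)c2cc(Cl)cc(C(F)(F)F)c2)cc1OC1CCN(C(=O)c2cccnc2)CC1`: compound 3 gives > 10000 nM, again a limit.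

Compound 1 and compound 2 differ in one place, (1,2-oxazol-5-yl in place of pyridin-3-yl on a carbonyl carbon). The step that the two limits leave unreadable from compound 1 to compound 2 cannot be read, since both ends sit at the limit of > 10000 nM in this assay, at which 3 of the 3 values shown sit. Compound 3 carries another core; the difference between the core of compound 3 and that of compound 1 is not broken down here. Compound 4 `Cc1ccc(NC(=O)c2cc(Cl)cc(C(F)(F)F)c2)cc1OC1CCN(C(=O)c2ccno2)CC1` is not yet measured. It differs from compound 3 by 1,2-oxazol-5-yl in place of pyridin-3-yl on a carbonyl carbon, the same kind of change as that from compound 1 to compound 2, though here the carbonyl carbon has an amide-type nitrogen in a ring as its other neighbour rather than an amide-type nitrogen. For the measured compounds named here, no measured step in this assay shows this change moving a value off the limit. For compound 4 the expected step that the limit leaves unreadable from compound 3 to compound 4 is essentially none, resting on compound 3 sitting at the limit of > 10000 nM in this assay, at which 3 of the 3 values shown sit, and on the unreadable step of the same kind. Compound 4 is estimated at 15000 nM, with a range from 4000 nM to 60000 nM, most likely reported again only as a limit.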

Compound 4, concentration for 50% growth inhibition: > 10000 nM
Compound 4: no number, only a limit (the forecaster's own chance of this, stated with the estimate: 85%); the middle value lies beyond the limit too.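

Compound 4 gives > 10000 nM in this assay, again a limit of the assay, so no step can be read from compound 3 to compound 4 or from compound 1 to compound 2: the limit of > 10000 nM in this assay, at which 4 of the 4 values shown sit.

The compounds shown leave open whether 1,2-oxazol-5-yl in place of pyridin-3-yl on a carbonyl carbon changes growth inhibition at all, on either core.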